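Growing a hydroxycyclobutyl into a dimethylated hydroxycyclohexyl ring

The source may report more compounds than this note shows. Statements on the series, on what has been measured and on what is new or still open speak of the compounds shown alone.

Two related compounds have been measured in an assay on isolated protein for inhibition of protein kinase C theta type (Homo sapiens), read by TR-FRET, with a stated time of 2 h; on this read-out higher numbers stand for weaker inhibition and lower numbers for stronger inhibition. Compound 1 `N#Cc1cnc(NCc2cnccc2C(F)(F)F)cc1N[C@H]1C[C@@H](O)C1` carries a 3-hydroxycyclobutyl group on a nitrogen on an aromatic ring and gives 500 nM in this assay, the higher of the two numbers and therefore the weaker inhibitor. Compound 2 `N#Cc1cnc(NCc2cncnc2OCC(F)F)cc1N[C@H]1CC[C@@H](O)CC1` differs from compound 1 in several places. In this assay compound 2 gives 90 nM, a number that sits beyond the usual scatter below that of compound 1.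

Compound 3 `CC1(C)C[C@H](Nc2cc(NCc3cnccc3C(F)(F)F)ncc2C#N)CC[C@H]1O` is the next compound to be tested. Relative to compound 1 it keeps the shared core and the trifluoromethyl-bearing side chain and differs only in 4-hydroxy-3,3-dimethylcyclohexyl in place of 3-hydroxycyclobutyl on a nitrogen on an aromatic ring. Among the measured compounds shown here, no step between two measured compounds isolates this change, so what can be said rests on the two numbers above. Since compound 2 with a six-membered hydroxy ring gives 90 nM while compound 1 gives 500 nM, a moderate gain is expected from compound 1 to compound 3 in this assay, estimated as a 2.8-fold lower number from compound 1 to compound 3 (0.44 log units; beyond the scatter). Compound 3 is therefore estimated at 180 nM in this assay, with a plausible range from 50 nM to 600 nM.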

Compound 3, half-maximal inhibitory concentration: 100 nM
For compound 3 the middle estimate is 1.8-fold (0.26 log units) above the measured one, and the stated range covers the measured number.
By their numbers in this assay, from the lowest: compounds 2 and 3 (each within the scatter of the next); then compound 1.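

Among the compounds shown here, this is the first comparison in which only one place changes: with the shared core and the trifluoromethyl-bearing side chain held constant, replacing 3-hydroxycyclobutyl with 4-hydroxy-3,3-dimethylcyclohexyl gives a 5.0-fold lower number from compound 1 to compound 3 (0.70 log units; beyond the scatter) in this assay. The position on the nitrogen therefore accepts a much larger group, going from 5 to 9 heavy atoms, and inhibition gets stronger rather than being lost, while the counts of hydrogen-bond donors and acceptors stay the same. Nothing shown here explains why the number falls, so this result records an effect without giving its cause.

As far as these compounds go, the change combines a larger ring with two added methyl groups, and the only ring without those methyl groups, in compound 2, comes with a different side chain, so the share of each in the step remains unknown. From the compounds shown here alone, it also remains open whether the hydroxy group itself matters at this position, a question that an amine or a methoxy group in its place on the same ring would help to answer.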